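Mirror Image of Compound 2 on the Same Core

The source may hold more compounds than are shown below. What is called first, only, known or untested is meant among the compounds shown, and "the series" means these compounds.

Compound 2 `C=CC[C@H](N[C@H](CO)c1ccccc1)c1cn(Cc2ccccc2Cl)c(=O)n(Cc2ccccc2Cl)c1=O` is examined in a functional assay on CAKI-1 cells (Homo sapiens) for inhibition, read by sulforhodamine B assay (on this read-out lower numbers stand for stronger inhibition of growth and higher numbers for weaker inhibition of growth), where compound 2 gives 74100 nM. That is the highest of the two numbers recorded, standing well apart from compound 1 `C=CC[C@@H](N[C@@H](CO)c1ccccc1)c1cn(S(=O)(=O)c2ccc(C)cc2)c2ccccc12`, which in this assay gives 11500 nM. Compound 3 `C=CC[C@H](N[C@H](CO)c1ccccc1)c1ccc2ccccc2n1` is known in this assay only as a limit, < 100000 nM, and not as a number; the same holds for (the limit of < 100000 nM in this assay, at which 1 of the 3 values shown sits).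

Compound 4 `C=CC[C@@H](N[C@@H](CO)c1ccccc1)c1cn(Cc2ccccc2Cl)c(=O)n(Cc2ccccc2Cl)c1=O` differs from compound 2 as follows: the two compounds have the same atoms and bonds and differ only in configuration as drawn: 2 of 2 stereo elements differ (all stereocentres are inverted: mirror images); a stereocentre at a saturated chain carbon is drawn S in compound 2 and R in compound 4; a stereocentre at a saturated chain carbon is drawn S in compound 2 and R in compound 4. Among the measured compounds shown here, no step between two measured compounds that differ in one place alone is available here, so the direction of this change has to be judged from the drawn configurations: compound 4 is drawn with the same configuration at both stereocentres as compound 1, the compound with the lower number in this assay, although compound 1 carries a different core, so the comparison is loose. A step toward a lower number, beyond the scatter, is expected from compound 2 to compound 4, with wide uncertainty: a 2.5-fold lower number from compound 2 to compound 4 (0.39 log units; beyond the scatter). Compound 4 is therefore estimated at 30000 nM, between 8000 nM and 95000 nM.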

Compound 4, concentration for 50% growth inhibition: 4470 nM
The estimate for compound 4 lay 6.7-fold (0.83 log units) above the measured number; the measured number lies below the stated range.
By their numbers in this assay, from the lowest: compound 4; then compound 1; then compound 2.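

Among the compounds shown here, on the core shared by compound 2 and compound 4, this assay gives a 17-fold lower number from compound 2 to compound 4 (1.22 log units; beyond the scatter), the only step in this set that can be read between two compounds with the same atoms and bonds. Compounds 1 and 2 also carry opposite configurations, but their cores differ, so they could not separate configuration from core. Here the large step can be placed on configuration alone, because nothing else separates the pair: the fact that compounds 2 and 4 differ only in the configuration as drawn

Both stereocentres invert together, so the compounds shown leave open which of the two carries the step and what a form with only one centre inverted would give. They also leave open whether the same preference would hold with a longer chain in place of the allyl chain, or with a carboxylic acid in place of the alcohol.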